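Moving the Hydroxy Group on the Shared Core of Compound 3

A few compounds are considered here, and "the series" means these few. Any claim that something is new, unique, unknown or untested is made for them only; others in the source may bear on it.

Three measured compounds share one core. Compound 1 `COc1ccccc1Nc1nc(-c2cccc(F)c2)nc2ccc(F)cc12` reaches only the limit > 50000 nM in a functional assay on U2OS cells (Homo sapiens) for cytotoxicity, read by MTT assay, with a stated time of 48 h; on this read-out lower numbers stand for stronger inhibition and higher numbers for weaker inhibition. Compound 2 `Fc1cccc(-c2nc(Nc3ccc(Cl)cc3)c3cc(F)ccc3n2)c1` gives 38400 nM in this assay. Compound 3 `Oc1ccc(Nc2nc(-c3cccc(F)c3)nc3ccc(F)cc23)cc1` likewise stops at the limit > 50000 nM in this assay. Compound 3 therefore stands at the ceiling of what the assay reports, (the limit of > 50000 nM in this assay, at which 2 of the 3 values shown sit). Compound 4 `Oc1cccc(Nc2nc(-c3cccc(F)c3)nc3ccc(F)cc23)c1` differs from compound 3 by 3-hydroxyphenyl in place of 4-hydroxyphenyl on a nitrogen on an aromatic ring. For the measured compounds named here, no measured step moves a hydroxy group around its ring; the nearest steps, an at least 1.3-fold lower number from compound 1 to compound 2 (0.11 log units; that floor lies within the scatter) and an at least 1.3-fold higher number from compound 2 to compound 3 (0.11 log units; that floor lies within the scatter), are small, and a step that the two limits leave unreadable from compound 1 to compound 3 cannot be read. Compound 4 is therefore expected to change little, a number no higher from compound 3 to compound 4 (the limit leaves the size open). The estimate for compound 4 is 50000 nM, spanning 20000 nM to 200000 nM.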

Compound 4, half-maximal inhibitory concentration: 33300 nM
Compound 4: middle estimate off by 1.5-fold (0.18 log units), on the high side, within the range that was stated.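

Moving the hydroxy group, with 3-hydroxyphenyl in place of 4-hydroxyphenyl, gives a hydroxy compound a measured number in this assay, but the readable shift is small: an at least 1.5-fold lower number from compound 3 to compound 4 (0.17 log units; that floor lies within the scatter). The other comparisons stay equally modest, with a 1.2-fold lower number from compound 2 to compound 4 (0.06 log units; within the scatter) and an at least 1.5-fold lower number from compound 1 to compound 4 (0.17 log units; that floor lies within the scatter). The true size of the two steps from limit values stays unknown, and the limit still marks part of the set: the limit of > 50000 nM in this assay, at which 2 of the 4 values shown sit.

The compounds shown leave open whether any group at this position can move the number beyond the scatter. An amine or a carboxylic acid on the same ring would test this.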